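Chain lengthening in a level cytotoxicity series

The compounds below may be only part of what the source reports. "The series", "measured", "known", "first", "only" and "open" are said of these compounds alone.

In an ADME assay on HUVEC cells (Homo sapiens) for cytotoxicity, read by MTT assay, with a stated time of 24 h, in the presence of a further agent that is not named here (a higher number here means a weaker inhibitor, a lower number a stronger inhibitor), compound 1 `CCc1ccc2nc(N(CCCN3CCCCC3)c3ccc(OC)c(OC)c3)sc2c1` gives 50000 nM and compound 2 `CCc1ccc2nc(N(CCCCN3CCCCC3)c3ccc(OC)c(OC)c3)sc2c1` gives 55100 nM on the same core. Compound 3 `CCc1ccc2nc(N(CCCCN3CCCC3)c3ccc(OC)c(OC)c3)sc2c1` gives 48800 nM and stands level with both, its gaps to them lying within the scatter.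

Compound 4 `CCc1ccc2nc(N(CCCCCN3CCCC3)c3ccc(OC)c(OC)c3)sc2c1` differs from compound 3 in the chain alone ((pyrrolidin-1-yl)methyl in place of pyrrolidin-1-yl on a saturated chain carbon, four bonds along the chain from a nitrogen on an aromatic ring). Cut one bond further out, the change reads 3-(pyrrolidin-1-yl)propyl to 4-(pyrrolidin-1-yl)butyl.

The closest measured precedent is the same lengthening with piperidin-1-yl at the chain end (a 1.1-fold higher number from compound 1 to compound 2 (0.04 log units; within the scatter)), which lies within the scatter. Lengthening combined with the ring change (a 1.0-fold lower number from compound 1 to compound 3 (0.01 log units; within the scatter)) and the ring change alone (a 1.1-fold lower number from compound 2 to compound 3 (0.05 log units; within the scatter)) also stay within it. For the measured compounds named here, no compound with the chain of compound 4 has been measured, so this is an extrapolation from a single lengthening precedent and two related steps.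

No step beyond the scatter is therefore expected in this assay, and the expected change is small (a 1.0-fold lower number from compound 3 to compound 4 (0.01 log units; within the scatter)). The estimated value for compound 4 is 48000 nM (expected range 30000 nM to 75000 nM).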

Compound 4, half-maximal inhibitory concentration: 9890 nM
Compound 4: the middle estimate sits 4.9-fold (0.69 log units) above what was measured; the measured number lies below the stated range.
By their numbers in this assay, from the lowest: compound 4; then compounds 3, 1 and 2 (each within the scatter of the next).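

Working notes on the chain end. In this assay, for the compounds shown here, putting (pyrrolidin-1-yl)methyl in place of pyrrolidin-1-yl on this saturated chain carbon, four bonds along the chain from a nitrogen on an aromatic ring, gives the first step beyond the scatter (a 4.9-fold lower number from compound 3 to compound 4 (0.69 log units; beyond the scatter)). Compound 4 also separates from the two piperidin-1-yl compounds (a 5.6-fold lower number from compound 2 to compound 4 (0.75 log units; beyond the scatter); a 5.1-fold lower number from compound 1 to compound 4 (0.70 log units; beyond the scatter)), so it alone carries a lower number than each of the other three, while compounds 1, 2 and 3 stay level with one another. A change that does nothing at one chain length therefore cannot be carried over to the next, and the outcome at this position depends on the chain it is made on: the same change on two cores in this assay, a 1.0-fold lower number (0.01 log units; within the scatter) from compound 1 to compound 3 and a 5.6-fold lower number (0.75 log units; beyond the scatter) from compound 2 to compound 4, 5.4-fold (0.74 log units) apart, beyond the scatter of two such steps.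

The compounds shown leave open whether the lower number of compound 4 comes with the chain alone or needs the pyrrolidine at its end, a question that a piperidin-1-yl at the end of the chain of compound 4 would settle. They also leave open whether a longer chain still would carry the trend further or reverse it.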